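Swapping an aryl ether for cyclohexyl on a triazole series

The source may report more compounds than this note shows. Statements on the series, on what has been measured and on what is new or still open speak of the compounds shown alone.

Of the compounds shown here, two sharing one core have been tested in a functional assay on CHO cells for antagonist activity at prostaglandin E2 receptor EP4 subtype (Homo sapiens), read by calcium flux, with a stated time of 15 min; on this read-out lower numbers stand for stronger inhibition and higher numbers for weaker inhibition. Compound 1 `C[C@H](NC(=O)c1c(-c2ccccc2)nnn1Cc1cccc(C(F)(F)F)c1)c1ccc(C(=O)O)cc1` gives 23 nM in this assay. Compound 2 `C[C@H](NC(=O)c1c(-c2ccccc2)nnn1CCOc1ccc(F)cc1)c1ccc(C(=O)O)cc1` gives 3.1 nM in this assay. Going by the values given here, the only change between them is (4-fluorophenoxy)methyl in place of 3-(trifluoromethyl)phenyl on a saturated chain carbon bound to an aromatic nitrogen, and that step, a 7.4-fold lower number from compound 1 to compound 2 (0.87 log units; beyond the scatter), makes compound 2 the stronger of the two numbers measured so far.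

Compound 3 `C[C@H](NC(=O)c1c(-c2ccccc2)nnn1CC1CCCCC1)c1ccc(C(=O)O)cc1` has not yet been measured in this assay. It differs from compound 2 by cyclohexyl in place of (4-fluorophenoxy)methyl on a saturated chain carbon bound to an aromatic nitrogen. Among the compounds with values here, the one measured step, from compound 1 to compound 2, bears on this only loosely: it shows that what hangs from the chain carbon bound to the aromatic nitrogen shifts the number by a modest amount, but neither measured compound carries a non-aromatic ring there, so there is no direct precedent. The expectation is a step of a 4.8-fold higher number from compound 2 to compound 3 (0.68 log units; beyond the scatter), a weaker number than compound 2 but with wide uncertainty. Compound 3 is therefore estimated at 15 nM, within a range from 4 nM to 60 nM.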

Compound 3, half-maximal inhibitory concentration: > 10000 nM
Compound 3: only a limit was reported (the forecaster's own chance of this, stated with the estimate: 3%); at least 660-fold (2.82 log units) between middle value and limit.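

In this assay, compound 3 gives only a limit and not a number: the limit of > 10000 nM in this assay, at which 1 of the 3 values shown sits.

Placing cyclohexyl on the saturated chain carbon bound to an aromatic nitrogen produces an at least 3200-fold higher number from compound 2 to compound 3 (3.50 log units; beyond the scatter), and the comparison with the other earlier compound shows an at least 430-fold higher number from compound 1 to compound 3 (2.63 log units; beyond the scatter). The earlier compounds suggested that this position shifts the number only modestly, but these large steps show that a change here can take a compound out of the measurable range altogether; among these three compounds, the two carrying a six-membered aromatic ring give numbers, and the one carrying a non-aromatic ring gives only a limit.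

Compound 3 differs from the other two both in losing the aromatic ring and in having neither fluorine nor trifluoromethyl on its ring, so these compounds cannot show which difference matters, nor how far past its limit compound 3 lies. An unsubstituted phenyl or a cyclohexyl ring bearing a trifluoromethyl group at this position would help separate the two, and a piperidine ring would test a ring amine there.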